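The compounds below may be only part of what the source reports. "The series", "measured", "known", "first", "only" and "open" are said of these compounds alone.

Measured so far:
Compound 1, `ClCc1cccc(Cn2cnc3ncnc(Cl)c32)c1`, gives 32400 nM.
Compound 2, `ClCc1cccc(Cn2cnc3c(Cl)ncnc32)c1`, gives 4360 nM.
Compound 3, `ClCc1cccc(Cn2cnc3c(Cl)nc(Cl)nc32)c1`, gives 3460 nM.

The three were tested in a functional assay on SW-620 cells (Homo sapiens) for cytotoxicity, read by sulforhodamine B assay, with a stated time of 48 h; on this read-out lower numbers stand for stronger inhibition of growth and higher numbers for weaker inhibition of growth. Compound 1 and compound 2 are built from the same atoms joined differently; the difference between the two cores is not broken down here. Compound 1 stands at the highest number of the three, with compound 2 at a number beyond the scatter below it, and compound 3 further still. From compound 2 to compound 3 the change is chloro in place of hydrogen on an aromatic carbon, and in this assay it gave a 1.3-fold lower number from compound 2 to compound 3 (0.10 log units; within the scatter).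

Compound 4, `ClCc1cccc(Cn2cnc3nc(Cl)nc(Cl)c32)c1`, has not been measured in this assay. It differs from compound 1 by chloro in place of hydrogen on an aromatic carbon, the same change as that from compound 2 to compound 3. On that single earlier step, which stayed within the scatter, compound 4 is expected to sit close to compound 1, with a step of about a 1.3-fold lower number from compound 1 to compound 4 (0.11 log units; within the scatter). The estimate for compound 4 in this assay is therefore 25000 nM, expected between 10000 nM and 60000 nM.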

Compound 4, concentration for total growth inhibition: 1650 nM
For compound 4 the middle estimate is 15-fold (1.18 log units) above the measured one; measured number outside the range, below it.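

On the core of compound 1, chloro in place of hydrogen on an aromatic carbon, between two ring nitrogen atoms, gave a 20-fold lower number from compound 1 to compound 4 (1.29 log units; beyond the scatter) in this assay. The same change did not carry over from one core to the other with the same size, and the two steps differ beyond the scatter: the same change on two cores in this assay, a 1.3-fold lower number (0.10 log units; within the scatter) from compound 2 to compound 3 and a 20-fold lower number (1.29 log units; beyond the scatter) from compound 1 to compound 4, 16-fold (1.19 log units) apart, beyond the scatter of two such steps This shows that, for these two pairs, the size of the step depends on the core, so a step read on one core was a poor guide to the other; it does not show why the two cores differ, and two pairs give no rule for any further core in the series.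

All four compounds carry chloro on the core, which leaves open whether an amine or a methoxy group in that same place would also give steps that differ between the two cores. From the compounds shown here alone, it also remains open whether the gap between the two steps would hold in another cell line.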